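A few compounds are considered here, and "the series" means these few. Any claim that something is new, unique, unknown or untested is made for them only; others in the source may bear on it.

Compound 1 `CCOc1cccc2c1S(=O)(=O)N=C2C1=C(O)[C@H](C(C)C)N(Cc2ccccc2)C1=O` stands at the top of what can be read in an ADME assay on Huh-7 cells (Homo sapiens) for cytotoxicity, with a stated time of 72 h; on this read-out higher numbers stand for lower toxicity in this test and lower numbers for higher toxicity in this test. In this assay compound 1 gives > 33000 nM, which is a limit of the assay and not a number. Compound 2 `CC(C)[C@H]1C(O)=C(C2=NS(=O)(=O)c3c(OCc4ncon4)cccc32)C(=O)N1Cc1ccccc1` gives > 33000 nM, which is also a limit. The record so far is therefore (the limit of > 33000 nM in this assay, at which 2 of the 2 values shown sit).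

Compound 3 `CCOc1cccc2c1S(=O)(=O)N=C2C1=C(O)[C@H](C(C)C)N(CCC(C)(C)C)C1=O` keeps the core of compound 1 and carries one change: neopentyl in place of phenyl on a saturated chain carbon bound to an amide-type nitrogen in a ring. In words, this is neopentyl in place of phenyl on a saturated chain carbon bound to an amide-type nitrogen in a ring, or benzyl to 3,3-dimethylbutyl when cut one bond further out. For the measured compounds named here, the only measured step is a step that the two limits leave unreadable from compound 1 to compound 2. It has no readable size and lies elsewhere on the molecule, so it gives no size to carry over. The expectation rests on compound 1 at > 33000 nM, and no change beyond the scatter is foreseen in this assay. The expected step is a number no higher from compound 1 to compound 3 (the limit leaves the size open). For compound 3 the estimated value is 33000 nM, with an expected range from 15000 nM to 60000 nM.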

Compound 3, half-maximal cytotoxic concentration: > 33000 nM
Compound 3: no number, only a limit (the forecaster's own chance of this, stated with the estimate: 75%); the middle value lies on the limit itself.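

No new step can be read from compound 1 to compound 3: in this assay both give only a limit and not a number. The compounds shown leave open where any of them would fall as a number and whether benzyl or 3,3-dimethylbutyl makes any difference on this read-out, with the record standing as follows: the limit of > 33000 nM in this assay, at which 3 of the 3 values shown sit.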